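Swapping the Isoxazole Ester for a Pyrimidine

This account rests on a few compounds, and the source may have more. Where it says the series, first, only, none or still open, it means among the compounds named here.

Of the compounds shown here, three sharing one core have been measured in a functional assay on Jurkat cells (Homo sapiens) for inhibition; on this read-out higher numbers stand for weaker inhibition and lower numbers for stronger inhibition. Compound 1 `CCOC(=O)c1c(C)noc1OCC(=O)[C@H](CC(=O)O)NC(=O)[C@@H](NC(=O)COc1cccc2ccccc12)C(C)C` gives only a limit of the assay, > 200000 nM. Compound 2 `CC(C)[C@H](NC(=O)COc1cccc2ccccc12)C(=O)N[C@@H](CC(=O)O)C(=O)CSc1nnc(-c2ccccc2)o1` gives 150000 nM. Compound 3 `CC(C)[C@H](NC(=O)COc1cccc2ccccc12)C(=O)N[C@@H](CC(=O)O)C(=O)COc1nc2ccccc2[nH]1` likewise gives only a limit, > 200000 nM. The step of an at least 1.3-fold lower number from compound 1 to compound 2 (0.12 log units; that floor lies within the scatter) lies within the scatter, and the step that the two limits leave unreadable from compound 1 to compound 3 cannot be read; the limit of > 200000 nM in this assay, at which 2 of the 3 values shown sit, keeps compound 1 from being placed any further than its limit. Compound 4 `CC(C)[C@H](NC(=O)COc1cccc2ccccc12)C(=O)N[C@@H](CC(=O)O)C(=O)COc1ccncn1` differs from compound 1 by pyrimidin-4-yl in place of 4-(ethoxycarbonyl)-3-methyl-1,2-oxazol-5-yl on an oxygen on a saturated carbon. Every measured step is small or unreadable, so no change beyond the scatter is expected for this step, an at least 1.3-fold lower number from compound 1 to compound 4 (0.12 log units; that floor lies within the scatter). Compound 4 is therefore expected to give 150000 nM, somewhere between 50000 nM and 300000 nM, with a fair chance of another limit.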

Compound 4, half-maximal inhibitory concentration: > 200000 nM
Compound 4 was reported as a limit; the forecaster's own chance of this, stated with the estimate: 55%; at least 1.3-fold (0.12 log units) between middle value and limit.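

Compound 4 gives > 200000 nM, which is a limit of the assay and not a number. For the compounds shown here, the one readable step is an at least 1.3-fold higher number from compound 2 to compound 4 (0.12 log units; that floor lies within the scatter). The steps from compound 1 and compound 3 cannot be read, so pyrimidin-4-yl on this oxygen gives no more of a measured difference than the groups before it, and the series stays at the end of the assay's range: the limit of > 200000 nM in this assay, at which 3 of the 4 values shown sit.

Going by these compounds, whether any group here can give real inhibition stays open. An amine on the pyrimidin-4-yl ring, or a longer chain carrying that ring, might or might not give a value inside the range.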